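Varying the carbamate chain on compound 2

This account rests on a few compounds, and the source may have more. Where it says the series, first, only, none or still open, it means among the compounds named here.

Compound 1: `CCCC(=O)OCC1CN(C(=O)c2cc(OC)c(OC)c(OC)c2)CCN1C(=O)c1cc(OC)c(OC)c(OC)c1` gives 420 nM in a functional assay (Oryctolagus cuniculus) for inhibition of platelet-activating factor receptor (Cavia porcellus); a higher number here means a weaker inhibitor, a lower number a stronger inhibitor.
Compound 2: `COc1cc(C(=O)N2CCN(C(=O)c3cc(OC)c(OC)c(OC)c3)C(COC(=O)NC(C)(C)C)C2)cc(OC)c1OC` gives 130 nM in this assay.

Among the compounds with values here, compound 2 holds the lower of the two numbers; the single measured step, a 3.2-fold lower number from compound 1 to compound 2 (0.51 log units; beyond the scatter), separates them. Compound 3 `CCCC(C)NC(=O)OCC1CN(C(=O)c2cc(OC)c(OC)c(OC)c2)CCN1C(=O)c1cc(OC)c(OC)c(OC)c1` differs from compound 2 by 1-methylbutyl in place of tert-butyl on an amide-type nitrogen. Within the data shown here, no measured step bears on this change: the only step available swaps the whole arm on the carbonyl carbon rather than one alkyl chain against another, so it gives no guide. For compound 3 no step beyond the scatter is expected, estimated as a 1.2-fold higher number from compound 2 to compound 3 (0.06 log units; within the scatter). Compound 3 is therefore estimated at 150 nM in this assay, with a range from 50 nM to 450 nM.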

Compound 3, half-maximal inhibitory concentration: 100 nM
Estimate against measurement, compound 3: 1.5-fold (0.18 log units) above, within the range that was stated.
By their numbers in this assay, from the lowest: compounds 3 and 2 (each within the scatter of the next); then compound 1.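

On the amide-type nitrogen, 1-methylbutyl serves as well as tert-butyl in this assay, with a 1.3-fold lower number from compound 2 to compound 3 (0.11 log units; within the scatter) and so no real separation between these two chains. The advantage over the propyl arm of compound 1 also holds with this second alkyl group on the nitrogen, with a 4.2-fold lower number from compound 1 to compound 3 (0.62 log units; beyond the scatter) as the measured step. No available evidence explains these results.

Still open, as far as these compounds go, is how a methyl group, a cyclohexyl ring or a chain ending in an amine or a carboxylic acid would read on this nitrogen. Replacing the amide hydrogen with a second methyl group is equally untested here.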